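A few compounds are considered here, and "the series" means these few. Any claim that something is new, unique, unknown or untested is made for them only; others in the source may bear on it.

- Compound 1 `CCCc1nn(C)c2c(NC3CC3)nc(/C=C/c3nc(C)c(C)nc3C)nc12`: 706000 nM
- Compound 2 `CCCCNc1nc(/C=C/c2ccccc2)nc2ccsc12`: > 1000000 nM (a limit)
- Compound 3 `FC(F)(F)c1ccc(Nc2nc(/C=C/c3ccccc3)nc3ccsc23)cc1`: > 1000000 nM (a limit)

All three values come from a functional assay on L02 cells (Homo sapiens) for inhibition, read by Griess assay, with stated times of 1 h and 24 h; on this read-out lower numbers stand for stronger inhibition and higher numbers for weaker inhibition. Only compound 1 has an actual number. Compound 2 has no number, only the limit > 1000000 nM. The same is true of compound 3, so the set so far is described by the limit of > 1000000 nM in this assay, at which 2 of the 3 values shown sit.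

Compound 4 `Brc1ccc(CNc2nc(/C=C/c3ccccc3)nc3ccsc23)cc1` keeps the core of compound 2 and changes one group: 4-bromophenyl in place of propyl on a saturated chain carbon bound to a nitrogen on an aromatic ring. In words, 4-bromophenyl stands in place of propyl on a saturated chain carbon bound to a nitrogen on an aromatic ring, so butyl becomes 4-bromobenzyl. For the measured compounds named here, no measured pair shows what a change of this kind does, so no step beyond the usual scatter is expected in this assay, in either direction. The expected step is an at least 1.1-fold lower number from compound 2 to compound 4 (0.04 log units; that floor lies within the scatter). For compound 4 the estimated value is 900000 nM, with an expected range of 300000 nM to 1500000 nM. A reported limit instead of a number would also be no surprise.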

Compound 4, half-maximal inhibitory concentration: > 1000000 nM
Compound 4 ended at the assay's limit; the forecaster's own chance of this, stated with the estimate: 65%; at least 1.1-fold (0.04 log units) between middle value and limit.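

Compound 4 gives > 1000000 nM, which is a limit and not a number. Compound 2 also stands at a limit, so no step can be read between these two compounds. Going by these compounds, whether butyl and 4-bromobenzyl differ in inhibition at all stays open.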